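The compounds below may be only part of what the source reports. "The series", "measured", "known", "first", "only" and "open" are said of these compounds alone.

Compound 3 `Cc1cc2c(c(N)nn2C)c(N2CCCCC2)n1` is the reference point of this account. In an assay on isolated protein for inhibition of MAP kinase-activated protein kinase 2 (Homo sapiens), read by mobility shift assay, tested at 30 uM (on this read-out lower numbers stand for less inhibition and higher numbers for more inhibition at the one concentration tested (going by the name of the read-out)), compound 3 gives 7%, which is the top figure among the three numbers available, although the gaps to the other two lie within the usual scatter. Compound 2 `CC(=O)Nc1nn(C)c2cc(-c3ccc(N4CCN(C)CC4)cc3)[nH]c(=O)c12` gives 5% in this assay, and compound 1 `Cc1cc2[nH]nc(N)c2c(N2CCCCC2)n1` gives -1%. Among the measured compounds shown here, the one step that has been measured, a number 8 percentage points higher from compound 1 to compound 3 (within the scatter), concerns methyl in place of hydrogen on an aromatic nitrogen and stays within the scatter. Compound 4 `Cc1cc2c(c(N)nn2C)c(N2CC[C@H](O)C2)n1` differs from compound 3 in another way: 3-hydroxypyrrolidin-1-yl in place of piperidin-1-yl on an aromatic carbon. For the measured compounds named here, no measured step touches this ring exchange, so nothing in the data points to a change in either direction; all three compounds sit near zero in this assay, and the closest analogy, compound 3 with 7%, hardly inhibits. Compound 4 is therefore expected to show a number 2 percentage points lower from compound 3 to compound 4 (within the scatter), a step of no consequence beyond the scatter. The estimate for compound 4 in this assay is 5%, expected to fall between -8% and 18%.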

Compound 4, a percentage reported as inhibition, at one concentration (the size of the read-out at that concentration, not a potency): 2%
Beside the measured number, compound 4's estimate is 3 percentage points above it; low and high end bracket the measured number.
By their numbers in this assay, from the lowest: compounds 1, 4, 2 and 3 (each within the scatter of the next).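

Up to this point, the only change measured was on an aromatic nitrogen. Here, 3-hydroxypyrrolidin-1-yl in place of piperidin-1-yl on an aromatic carbon next to the ring nitrogen gives a number 5 percentage points lower from compound 3 to compound 4 (within the scatter) in this assay. A five-membered ring bearing a hydroxyl can thus replace the six-membered ring at this position with no change beyond the scatter, and the read-out stays near zero. Nothing available explains this result.

The compounds shown leave open whether an amine or a carboxylic acid at this position, or the other stereoisomer of 3-hydroxypyrrolidin-1-yl, would move the number beyond the scatter. They also leave open whether a morpholine ring or a longer chain here would give clear inhibition on the shared core.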